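Bromo for Nitro on a Weak Histone Acetyltransferase Inhibitor

The source may report more compounds than this note shows. Statements on the series, on what has been measured and on what is new or still open speak of the compounds shown alone.

Measured so far:
Compound 1, `Cc1cnc2sn(-c3ccc(Oc4ccccc4)cc3)c(=O)c2c1`, gives 12900 nM in an assay for inhibition of histone acetyltransferase KAT2B (Homo sapiens), read by fluorescence; a lower number here means a stronger inhibitor, a higher number a weaker inhibitor.
Compound 2, `Cc1cnc2sn(-c3ccc([N+](=O)[O-])cc3)c(=O)c2c1`, gives 15300 nM in this assay.

Among the compounds with values here, compound 2 is one of only two measured compounds, and the step of a 1.2-fold higher number from compound 1 to compound 2 (0.07 log units; within the scatter) places it alongside compound 1 rather than apart from it. Compound 3, `Cc1cnc2sn(-c3ccc(Br)cc3)c(=O)c2c1`, carries the change (bromo in place of nitro on an aromatic carbon). Within the data shown here, the only measured step that touches this position is the one from compound 1 to compound 2, where a phenoxy group gave way to nitro with no effect beyond the scatter; no step with bromo at this carbon has been measured. On that basis compound 3 is expected to show a step of a 1.1-fold lower number from compound 2 to compound 3 (0.04 log units; within the scatter) in this assay, a change of no size beyond the scatter in either direction. Compound 3 is therefore estimated at 14000 nM, with a range from 6000 nM to 35000 nM.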

Compound 3, half-maximal inhibitory concentration: 2990 nM
Estimate against measurement, compound 3: 4.7-fold (0.67 log units) above, and the stated range ends above it.
By their numbers in this assay, from the lowest: compound 3; then compounds 1 and 2 (each within the scatter of the next).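

In this assay, the earlier pair suggested that this aromatic carbon tolerated very different groups with little consequence, but the position does respond to its substituent: bromo gives a clear change against both nitro (a 5.1-fold lower number from compound 2 to compound 3 (0.71 log units; beyond the scatter)) and phenoxy (a 4.3-fold lower number from compound 1 to compound 3 (0.63 log units; beyond the scatter)). Compound 3 is thus the strongest inhibitor of the three, and the swap from nitro replaces a group of three heavy atoms and two hydrogen-bond acceptors with a single bromine atom and no acceptors. No measurement shown here explains why bromo lowers the number.

The compounds shown leave open whether this drop is particular to bromo or would also appear with chloro, or with an amine or a carboxylic acid on the same carbon. They also leave open whether the bromo effect would hold with a change elsewhere on the shared core.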